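Swapping 4-methylphenyl for (furan-2-yl)methyl on the shared core

The source may hold more compounds than are shown below. What is called first, only, known or untested is meant among the compounds shown, and "the series" means these compounds.

Compound 3 (`Cc1ccc(Nc2ncc(Cl)c(Nc3ccccc3C)n2)cc1`) gives > 100000 nM in a functional assay on MDA-MB-231 cells (Homo sapiens) for inhibition, read by CCK-8 assay, with a stated time of 48 h (on this read-out lower numbers stand for stronger inhibition of growth and higher numbers for weaker inhibition of growth), and this is a limit, not a number. Compound 2 (`Cc1ccccc1Nc1nc(NC2CCCCC2)ncc1Cl`) gives > 100000 nM in this assay and this too is a limit. Both compounds thus stand at the limit of > 100000 nM in this assay, at which 2 of the 3 values shown sit, and no number is known for either. Compound 1 (`Cc1ccccc1Nc1nc(Nc2cccnc2)ncc1Cl`) alone has a measured number, with 41200 nM in this assay as its result.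

Compound 4 (`Cc1ccccc1Nc1nc(NCc2ccco2)ncc1Cl`) keeps the shared core and has (furan-2-yl)methyl in place of 4-methylphenyl on a nitrogen on an aromatic ring. The measured steps at this same place are few. Putting 4-methylphenyl in place of pyridin-3-yl gave (an at least 2.4-fold higher number from compound 1 to compound 3 (0.38 log units; beyond the scatter)), and cyclohexyl in the same place gave (an at least 2.4-fold higher number from compound 1 to compound 2 (0.38 log units; beyond the scatter)). The exchange between those two groups gave (a step that the two limits leave unreadable from compound 2 to compound 3) and so offers no size.

The entering group has a hetero atom in its ring, as pyridin-3-yl does, so a modest move toward lower numbers is expected, though compound 4 may also stay at the limit. The expected step is an at least 1.6-fold lower number from compound 3 to compound 4 (0.22 log units; that floor lies within the scatter) by this estimate. In this assay compound 4 is estimated at 60000 nM with an expected range from 20000 nM to 130000 nM for now.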

Compound 4, concentration for 50% growth inhibition: > 100000 nM
Compound 4 gave a limit, no number; the forecaster's own chance of this, stated with the estimate: 45%; middle value at least 1.6-fold (0.22 log units) away from the limit.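

In this assay, compound 4 is another compound that gives only a limit: the limit of > 100000 nM in this assay, at which 3 of the 4 values shown sit. This shows that a hetero atom in the entering ring is not enough at this place: (furan-2-yl)methyl carries one, as pyridin-3-yl does, yet exchanging pyridin-3-yl for it gave an at least 2.4-fold higher number from compound 1 to compound 4 (0.38 log units; beyond the scatter). Pyridin-3-yl therefore remains the only one of the four groups on this nitrogen with a measured number, while the steps from compound 4 to compound 2 and compound 3 cannot be read, as both ends of each are limits.

The change to (furan-2-yl)methyl alters the ring and puts a methyl link on the nitrogen at once, so the compounds shown do not separate these two features, and a (pyridin-3-yl)methyl group or a directly attached furan-3-yl group would bear on that question. Also open, going by these compounds, is whether pyridin-4-yl or pyrimidin-5-yl would keep a measured number in this assay, and how far compound 2, compound 3 and compound 4 really differ.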